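Three close values and one untested hydroxy compound

The source may report more compounds than this note shows. Statements on the series, on what has been measured and on what is new or still open speak of the compounds shown alone.

In a functional assay on HCT-8 cells (Homo sapiens) for cytotoxicity (a lower number here means that less compound is needed, a higher number that more compound is needed for the effect), compound 1 (`COC1=C(C)C(=O)/C(=C(O)/C=C/c2ccc(Br)cc2)C(=O)C1(C)C`) gives 7.4 ug/mL, compound 2 (`COC1=C(C)C(=O)/C(=C(O)/C=C/c2ccc(OC)cc2)C(=O)C1(C)C`) gives 5.6 ug/mL and compound 3 (`COC1=C(C)C(=O)/C(=C(O)/C=C/c2ccccc2OC)C(=O)C1(C)C`) gives 4.1 ug/mL. Compound 3 is not clearly separated from the other two. The measured steps are a 1.8-fold lower number from compound 1 to compound 3 (0.26 log units; within the scatter), and a 1.4-fold lower number from compound 2 to compound 3 (0.14 log units; within the scatter). Compound 4 (`COC1=C(C)C(=O)/C(=C(O)/C=C/c2ccc(O)cc2)C(=O)C1(C)C`) brings one change: 4-hydroxyphenyl in place of 2-methoxyphenyl on a double-bonded chain carbon bound to a double-bonded chain carbon. Going by the values given here, no measured compound carries 4-hydroxyphenyl, so the data cannot test this group directly. The closest guide is the other change on the aromatic ring, a 1.3-fold lower number from compound 1 to compound 2 (0.12 log units; within the scatter), which also stays small. A shift beyond the scatter is therefore not expected, and the expected step is a 1.3-fold higher number from compound 3 to compound 4 (0.10 log units; within the scatter). For compound 4 the estimated value is 5.2 ug/mL, with an expected range of 2.5 ug/mL to 11 ug/mL.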

Compound 4, concentration for half-maximal effect: 14.8 ug/mL
Beside the measured number, compound 4's estimate is 2.8-fold (0.45 log units) below it, and the stated range ends below it.
By their numbers in this assay, from the lowest: compounds 3, 2, 1 and 4 (each within the scatter of the next, the first and the last beyond it).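

Going by these compounds alone, on the double-bonded chain carbon, 4-hydroxyphenyl brings the first steps beyond the scatter in this assay (a 3.6-fold higher number from compound 3 to compound 4 (0.56 log units; beyond the scatter)) and (a 2.6-fold higher number from compound 2 to compound 4 (0.42 log units; beyond the scatter)). The second of these is only hydrogen in place of methyl on an oxygen on an aromatic ring, so this small change can matter here, though both steps are modest. The new group does not separate from bromo, however (a 2.0-fold higher number from compound 1 to compound 4 (0.30 log units; within the scatter)).

Nothing measured here explains the shift. Going by these compounds, whether an amine or a carboxylic acid in place of the hydroxy group would move the number further remains open.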